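A few compounds are considered here, and "the series" means these few. Any claim that something is new, unique, unknown or untested is made for them only; others in the source may bear on it.

Measured in a functional assay on SW1573 cells (Homo sapiens) for antiproliferative activity; on this read-out lower numbers stand for higher toxicity in this test and higher numbers for lower toxicity in this test:
Compound 1 `C[Si](C)(C)C1=C(Cl)C[C@H](C2CCCCC2)O[C@@H]1C1CCCCC1`: 88000 nM
Compound 2 `C[C@@H]1O[C@H](CCC=C(Br)Br)C([Si](C)(C)C)=C(Cl)[C@H]1C`: 87000 nM

On these two numbers compound 2 stands lowest, with compound 1 within the scatter of it, so the two cannot be told apart. Compound 3 `C=CCC[C@H]1O[C@@H](C)[C@H](C)C(Cl)=C1[Si](C)(C)C` differs from compound 2 by one change: vinyl in place of 2,2-dibromoethenyl on a saturated chain carbon, two bonds along the chain from a saturated ring carbon. Among the compounds with values here, no step between measured compounds covers this change, so there is no measured basis for its size. The expectation is a step from compound 2 to compound 3 of a 1.3-fold higher number from compound 2 to compound 3 (0.10 log units; within the scatter), toward a higher number, if anything. Compound 3 is estimated at 110000 nM, within 35000 nM to 350000 nM.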

Compound 3, concentration lethal to 50% of the cells: 92000 nM
Compound 3: the middle estimate sits 1.2-fold (0.08 log units) above what was measured, and the stated range covers the measured number.
By their numbers in this assay, from the lowest: compounds 2, 1 and 3 (each within the scatter of the next).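

Swapping the 2,2-dibromoethenyl group for vinyl removes both bromine atoms and keeps the double bond, and in this assay this gives a 1.1-fold higher number from compound 2 to compound 3 (0.02 log units; within the scatter) as the step. At this place on the chain, the two bromine atoms can therefore be lost with the two numbers remaining indistinguishable. Nothing measured here offers an explanation for this result. From the compounds shown here alone, whether an amine or a carboxylic acid at the end of this chain would separate from these numbers stays open. So does the effect of a longer chain.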